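A few compounds are considered here, and "the series" means these few. Any claim that something is new, unique, unknown or untested is made for them only; others in the source may bear on it.

Measured so far in an ADME assay on a cell-free system (plasma, Homo sapiens) for metabolic stability, with Plasma (Rattus norvegicus) as the target, read by HPLC, at pH 7.4; a lower number here means that the compound disappears faster, a higher number that the compound lasts longer:
compound 1 `CCCCC(=O)O[C@@H]1CO[C@H]2[C@@H]1OC[C@@H]2OC(=O)c1ccccc1OC(C)=O` gives 0.0198 h
compound 2 `CC(=O)Oc1ccccc1C(=O)O[C@H]1CO[C@H]2[C@@H]1OC[C@H]2OC(=O)c1ccccc1C` gives 0.035 h
compound 3 `COc1cccc(C(=O)O[C@@H]2CO[C@H]3[C@@H]2OC[C@@H]3OC(=O)c2ccccc2OC(C)=O)c1` gives 0.0525 h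

Compound 3 stands at the top of these three numbers. Its distance to compound 2 is small, a 1.5-fold higher number from compound 2 to compound 3 (0.18 log units; within the scatter), so these two cannot be ranked against each other. Against compound 1 the gap is larger, a 2.7-fold higher number from compound 1 to compound 3 (0.42 log units; beyond the scatter), a modest step that does reach beyond the scatter.

Compound 4 `CC(=O)Oc1ccccc1C(=O)O[C@H]1CO[C@H]2[C@@H]1OC[C@H]2OC(=O)CO[N+](=O)[O-]` differs from compound 3 in one place: (nitrooxy)methyl in place of 3-methoxyphenyl on a carbonyl carbon

Among the measured compounds shown here, the most telling step in hand is the one from compound 1 to compound 3, where a butyl chain on the same carbonyl carbon was swapped for an aromatic ring and the half-life in this assay rose, a 2.7-fold higher number from compound 1 to compound 3 (0.42 log units; beyond the scatter). The change to compound 4 runs the other way, from an aromatic ring back to a short non-aromatic group, so a drop of roughly that size is expected. Compound 4 is therefore estimated at 0.02 h, in the range 0.008 h to 0.05 h, a step of a 2.6-fold lower number from compound 3 to compound 4 (0.42 log units; beyond the scatter) expected.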

Compound 4, half-life: 0.06 h
Compound 4: middle estimate off by 3.0-fold (0.48 log units), on the low side, outside the stated range (above it).
By their numbers in this assay, from the lowest: compounds 1, 2, 3 and 4 (each within the scatter of the next, the first and the last beyond it).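

On this carbonyl carbon an aromatic ring turns out not to be required for the half-life in this assay: (nitrooxy)methyl, which has no ring, cannot be told apart from 3-methoxyphenyl (a 1.1-fold higher number from compound 3 to compound 4 (0.06 log units; within the scatter)) or from 2-methylphenyl (a 1.7-fold higher number from compound 2 to compound 4 (0.23 log units; within the scatter)). With nitrooxy in place of propyl on the saturated chain carbon bound to the carbonyl carbon, there is a 3.0-fold higher number from compound 1 to compound 4 (0.48 log units; beyond the scatter) and so compound 4 goes against any reading in which only aromatic groups outlast the butyl chain of compound 1. Nothing at hand explains this result.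

On these data alone, whether other non-aromatic groups on this carbonyl carbon, such as an amine or a carboxylic acid, follow (nitrooxy)methyl or butyl stays open. A plain methyl there would help separate the part played by nitrooxy from that of a short chain.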